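Amide for Acid on the Pyrrolidine Urea

The source may report more compounds than this note shows. Statements on the series, on what has been measured and on what is new or still open speak of the compounds shown alone.

Compound 1 `Cc1cc(C(=O)N2CCCCc3ccccc32)ccc1CNC(=O)NCC(=O)O`: 180 nM
Compound 2 `Cc1cc(C(=O)N2CCCCc3ccccc32)ccc1CNC(=O)NCC(=O)N1CCCCC1`: 150 nM
Compound 3 `Cc1cc(C(=O)N2CCCCc3ccccc32)ccc1CNC(=O)N1CCC[C@H]1C(=O)O`: 680 nM
Compound 4 `Cc1cc(C(=O)N2CCCCc3ccccc32)ccc1CNC(=O)N1CCC[C@@H]1C(=O)N(C)C`: not yet measured

In a functional assay on HEK293 cells for agonist activity at Vasopressin V2 receptor (Homo sapiens), read by a luciferase reporter and cAMP accumulation (on this read-out lower numbers stand for an effect already at smaller amounts and higher numbers for an effect only at larger amounts of compound), compound 3 gives 680 nM, the highest of the three numbers measured. The nearest is compound 1, with a 3.8-fold higher number from compound 1 to compound 3 (0.58 log units; beyond the scatter); the furthest is compound 2, with a 4.5-fold higher number from compound 2 to compound 3 (0.66 log units; beyond the scatter). Compound 4 differs from compound 3 by 2-(dimethylcarbamoyl)pyrrolidin-1-yl in place of 2-carboxypyrrolidin-1-yl on a carbonyl carbon. Going by the values given here, the one measured step that bears on this change is the exchange of hydroxy for piperidin-1-yl on a carbonyl carbon, a 1.2-fold lower number from compound 1 to compound 2 (0.08 log units; within the scatter), which stayed within the scatter. Compound 4 is therefore expected to show a 1.1-fold lower number from compound 3 to compound 4 (0.05 log units; within the scatter), with no shift beyond the scatter. Compound 4 is estimated at 600 nM, within a range from 250 nM to 1500 nM.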

Compound 4, half-maximal effective concentration: 380 nM
Estimate against measurement, compound 4: 1.6-fold (0.20 log units) above; low and high end bracket the measured number.
By their numbers in this assay, from the lowest: compounds 2 and 1 (each within the scatter of the next); then compounds 4 and 3 (each within the scatter of the next).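

In this assay, 2-(dimethylcarbamoyl)pyrrolidin-1-yl in place of 2-carboxypyrrolidin-1-yl gives a 1.8-fold lower number from compound 3 to compound 4 (0.25 log units; within the scatter), so on the pyrrolidine urea, too, the acid gives way to an amide without a shift beyond the scatter. The amide does not close the gap to the two compounds without the pyrrolidine, with a 2.5-fold higher number from compound 2 to compound 4 (0.40 log units; beyond the scatter) and a 2.1-fold higher number from compound 1 to compound 4 (0.32 log units; beyond the scatter). No data shown account for these steps.

The stereocentre is drawn with opposite arrangement in compound 3 and compound 4, so this pair does not separate the amide from the configuration. On these data alone, how a methyl ester or a primary carboxamide would behave at this place stays open.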